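Methylation of the aromatic hydroxy across two pyrazole-enaminone cores

The compounds below may be only part of what the source reports. "The series", "measured", "known", "first", "only" and "open" are said of these compounds alone.

Measured compounds:
compound 1, `O=C(/C=C\Nc1ccc(O)cc1)c1cn(-c2ccccc2)nc1-c1ccccc1`, 3210 nM
compound 2, `COc1ccc(N/C=C\C(=O)c2cn(-c3ccccc3)nc2-c2ccccc2)cc1`, 3250 nM
compound 3, `COc1cc(-c2nn(-c3ccccc3)cc2C(=O)/C=C\Nc2ccc(O)cc2)cc(OC)c1OC`, 3160 nM

In a functional assay on A549 cells (Homo sapiens) for antiproliferative activity, read by MTT assay, with a stated time of 48 h (a lower number here means a stronger inhibitor, a higher number a weaker inhibitor), compound 1 gives 3210 nM and compound 2 gives 3250 nM. The change between them is methyl in place of hydrogen on an oxygen on an aromatic ring, and the step it made is a 1.0-fold higher number from compound 1 to compound 2 (0.01 log units; within the scatter), so the two values cannot be told apart in this assay.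

Compound 3 carries a different core; how the core of compound 3 differs from the core of compound 1 is not broken down here. In this assay compound 3 gives 3160 nM, which sits within the scatter of compound 1 and of compound 2.

Compound 4, `COc1ccc(N/C=C\C(=O)c2cn(-c3ccccc3)nc2-c2cc(OC)c(OC)c(OC)c2)cc1`, is not yet measured. It differs from compound 3 by methyl in place of hydrogen on an oxygen on an aromatic ring, the same change that turns compound 1 into compound 2, made at the same place. Because a 1.0-fold higher number from compound 1 to compound 2 (0.01 log units; within the scatter) left the value unchanged within the scatter, the step from compound 3 to compound 4 is expected to be a 1.0-fold higher number from compound 3 to compound 4 (0.01 log units; within the scatter). This rests on a single measured pair, so the expectation is loose. Compound 4 is estimated to give 3200 nM in this assay, with a likely range from 1600 nM to 6500 nM.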

Compound 4, half-maximal inhibitory concentration: 4780 nM
The estimate for compound 4 lay 1.5-fold (0.17 log units) below the measured number, within the range that was stated.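

In this assay, methyl in place of hydrogen on the oxygen of the 4-hydroxyphenyl group gives steps on the two cores that cannot be told apart: the same change on two cores in this assay, a 1.0-fold higher number (0.01 log units; within the scatter) from compound 1 to compound 2 and a 1.5-fold higher number (0.18 log units; within the scatter) from compound 3 to compound 4, 1.5-fold (0.17 log units) apart, within the scatter of two such steps.

On the core of compound 3 the change gives a 1.5-fold higher number from compound 3 to compound 4 (0.18 log units; within the scatter), and with the 4-methoxyphenyl group held fixed, 3,4,5-trimethoxyphenyl in place of phenyl gives a 1.5-fold higher number from compound 2 to compound 4 (0.17 log units; within the scatter), so neither step can be separated from no change at all. The hydroxy to methoxy exchange can therefore be carried between these two cores without a detectable shift in this readout, but the evidence is two pairs and does not establish that the same holds on any further core, or that a change with a clear effect on one core would carry over to another.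

Whether anything at this oxygen can move the value beyond the scatter remains open, since the compounds shown hold only hydrogen or methyl there. A longer chain such as propyl on that oxygen, or an amine or a carboxylic acid in place of the hydroxy on the aromatic ring, would test this more severely than the methyl step.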